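Carrying a bromo-to-hydrogen step across to a second core

This account rests on a few compounds, and the source may have more. Where it says the series, first, only, none or still open, it means among the compounds named here.

Compound 1 `COc1ccc(NC(=O)Nc2nc(-c3cc4ccccc4o3)cs2)cc1` gives 17400 nM in a physicochemical assay, with a stated time of 6 min; on this read-out higher numbers stand for weaker inhibition and lower numbers for stronger inhibition. Compound 3 `O=C(Nc1nc(-c2cc3cc(Br)ccc3o2)cs1)Nc1ccccc1[N+](=O)[O-]` gives 166000 nM in this assay. For compound 2 `COc1ccc(NC(=O)Nc2nc(-c3cc4cc(Br)ccc4o3)cs2)cc1` the result in this assay is only a limit, > 200000 nM, namely (the limit of > 200000 nM in this assay, at which 1 of the 3 values shown sits). Compound 2 and compound 1 differ by hydrogen in place of bromo on an aromatic carbon, and the measured step is an at least 11-fold lower number from compound 2 to compound 1 (1.06 log units; beyond the scatter). The two cores differ by 2-nitrophenyl in place of 4-methoxyphenyl on an amide-type nitrogen, with a step of an at least 1.2-fold lower number from compound 2 to compound 3 (0.08 log units; that floor lies within the scatter). Compound 4 `O=C(Nc1nc(-c2cc3ccccc3o2)cs1)Nc1ccccc1[N+](=O)[O-]` is not yet measured; it differs from compound 3 by hydrogen in place of bromo on an aromatic carbon, the same change as between compound 2 and compound 1, at a place described in identical words. For compound 4 a step of an 11-fold lower number from compound 3 to compound 4 (1.04 log units; beyond the scatter) is expected, set beside an at least 11-fold lower number from compound 2 to compound 1 (1.06 log units; beyond the scatter), since that measured pair is the only other occurrence of this change here. Compound 4 is thus estimated at 15000 nM, between 4000 nM and 60000 nM.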

Compound 4, half-maximal inhibitory concentration: 20300 nM
For compound 4 the middle estimate is 1.4-fold (0.13 log units) below the measured one; measured number inside the range.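

In this assay, hydrogen in place of bromo on the core of compound 3 gives an 8.2-fold lower number from compound 3 to compound 4 (0.91 log units; beyond the scatter), the same direction as an at least 11-fold lower number from compound 2 to compound 1 (1.06 log units; beyond the scatter). With hydrogen on the aromatic carbon, the 2-nitrophenyl and 4-methoxyphenyl compounds stand within the scatter of each other, with a 1.2-fold higher number from compound 1 to compound 4 (0.07 log units; within the scatter). Compound 2 has only a limit of the assay, > 200000 nM, so the sizes of the two bromo-to-hydrogen steps cannot be compared, and the change is shown to carry over in direction only, on these two cores.

Still open, on these data alone, is how a chloro group, an amine or a carboxylic acid on that aromatic carbon would read. Also open, as far as these compounds go, is whether the same direction holds with other groups on the amide-type nitrogen.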